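Shifting the pyridine nitrogen once more on the alkyne arm

The compounds below may be only part of what the source reports. "The series", "measured", "known", "first", "only" and "open" are said of these compounds alone.

Within the data shown here, compound 2 `Cc1ccc(-n2nccn2)c(C(=O)N2C[C@H](C#Cc3ccc(CO)cn3)CC[C@H]2C)c1` gives 130 nM in an assay on cells for binding affinity to Orexin receptor type 2 (Homo sapiens), read by radioligand binding (a higher number here means a weaker inhibitor, a lower number a stronger inhibitor), the lower of the two numbers measured so far, though its gap to compound 1 `Cc1ccc(-n2nccn2)c(C(=O)N2C[C@H](C#Cc3ccc(CO)nc3)CC[C@H]2C)c1`, which gives 150 nM, lies within the scatter. The move from compound 2 to compound 3 `Cc1ccc(-n2nccn2)c(C(=O)N2C[C@H](C#Cc3cncc(CO)c3)CC[C@H]2C)c1` is 5-(hydroxymethyl)pyridin-3-yl in place of 5-(hydroxymethyl)pyridin-2-yl on a triple-bonded carbon. Among the measured compounds shown here, the one comparable step, a 1.2-fold lower number from compound 1 to compound 2 (0.06 log units; within the scatter), also rearranged the same ring and changed nothing beyond the scatter. No step beyond the scatter is therefore expected here, and compound 3 is estimated at 150 nM, between 60 nM and 400 nM, an expected step of a 1.2-fold higher number from compound 2 to compound 3 (0.06 log units; within the scatter).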

Compound 3, inhibition constant: 32 nM
Compound 3: the middle estimate sits 4.7-fold (0.67 log units) above what was measured, and the stated range ends above it.
By their numbers in this assay, from the lowest: compound 3; then compounds 2 and 1 (each within the scatter of the next).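

Placing 5-(hydroxymethyl)pyridin-3-yl on the triple-bonded carbon gives a 4.1-fold lower number from compound 2 to compound 3 (0.61 log units; beyond the scatter) in this assay, and a 4.7-fold lower number from compound 1 to compound 3 (0.67 log units; beyond the scatter) as well. The same atoms, joined differently within this ring, can therefore move the number beyond the scatter, and of the three arrangements only this one stands apart from the other two. Nothing available explains why this arrangement differs. Still open, as far as these compounds go, is whether the hydroxymethyl group is needed at all, and how an aminomethyl group or a carboxylic acid would fare in its place on compound 3.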